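Compound 3: methyl in place of chloro

The source may report more compounds than this note shows. Statements on the series, on what has been measured and on what is new or still open speak of the compounds shown alone.

Going by the values given here, in a functional assay on PC-3 cells (Homo sapiens) for antiproliferative activity (a higher number here means a weaker inhibitor of growth, a lower number a stronger inhibitor of growth), compound 2 `Cc1cc(C)c2c(O)cc(-c3cccc(Cl)c3)nc2n1` holds the lower of the two numbers so far at 27.5 nM against compound 1 `Cc1cc(C)c2c(O)cc(-c3cccc(F)c3)nc2n1` at 61.7 nM on the same read-out. Compound 3 `Cc1cccc(-c2cc(O)c3c(C)cc(C)nc3n2)c1` has methyl in place of chloro on an aromatic carbon, meta to a large group, and the difference from compound 2 is methyl in place of chloro on an aromatic carbon in full. Among the compounds with values here, one measured step bears on this change: a 2.2-fold lower number from compound 1 to compound 2 (0.35 log units; beyond the scatter) for chloro in place of fluoro, which is modest and beyond the scatter. Within the data shown here, no measured compound carries methyl on that ring, so the data do not fix the direction. Given that compound 2 holds the lower number, a modest move toward a higher number in this assay is expected. The expected change is a 1.8-fold higher number from compound 2 to compound 3 (0.26 log units; within the scatter) in this estimate. For compound 3 the estimated value is 50 nM with an expected range of 20 nM to 125 nM as the working figure.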

Compound 3, concentration for 50% growth inhibition: 31600 nM
The estimate for compound 3 lay 630-fold (2.80 log units) below the measured number; the measured number lies above the stated range.
By their numbers in this assay, from the lowest: compound 2; then compound 1; then compound 3.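

In this assay, this aromatic carbon proves far less forgiving than the halogen pair suggested: methyl in place of chloro gives a 1100-fold higher number from compound 2 to compound 3 (3.06 log units; beyond the scatter), and methyl in place of fluoro gives a 510-fold higher number from compound 1 to compound 3 (2.71 log units; beyond the scatter). Both steps dwarf the halogen swap, a 2.2-fold lower number from compound 1 to compound 2 (0.35 log units; beyond the scatter), even though each exchanges one heavy atom for one heavy atom and the count of hydrogen-bond donors and acceptors stays at 0 on both sides, so among these compounds the two halogens keep the number low and methyl alone does not. Nothing available explains why this single-atom exchange costs so much.

Still open, on these data alone, is whether bromo or trifluoromethyl on this carbon would stay with the halogen compounds or move toward compound 3. Equally open, as far as these compounds go, is where methoxy or an amine would fall, and so whether methyl is a special case or one of many poor groups here.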